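Piperidinyl to isopropylamino on the chloro-pyrazine amide core

A few compounds are considered here, and "the series" means these few. Any claim that something is new, unique, unknown or untested is made for them only; others in the source may bear on it.

Measured in an assay on Ltk cells for inhibition of metabotropic glutamate receptor 5 (Homo sapiens), read by fluorescence; on this read-out higher numbers stand for weaker inhibition and lower numbers for stronger inhibition:
- compound 1 `CN(C)c1nc(N)c(C(=O)Nc2ccccn2)nc1Cl` gives 134 nM
- compound 2 `CN(C)c1ncc(C(=O)Nc2ccccn2)nc1Cl` gives 158 nM
- compound 3 `Nc1nc(N2CCCCC2)c(Cl)nc1C(=O)Nc1ccccn1` gives 103 nM

Compound 3 holds the lowest number of the three, but its separation from the others is not beyond the scatter: compound 1 differs by a 1.3-fold lower number from compound 1 to compound 3 (0.11 log units; within the scatter), and compound 2 lies a little higher again. The two measured steps are both small. Removing the amino group gave a 1.2-fold higher number from compound 1 to compound 2 (0.07 log units; within the scatter), and exchanging dimethylamino for piperidin-1-yl gave a 1.3-fold lower number from compound 1 to compound 3 (0.11 log units; within the scatter).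

Compound 4 `CC(C)Nc1nc(N)c(C(=O)Nc2ccccn2)nc1Cl` carries isopropylamino in place of piperidin-1-yl on an aromatic carbon. Only the dimethylamino-to-piperidinyl step bears directly on variation at this carbon, and it stayed inside the scatter. Among the compounds with values here, no measured compound carries a hydrogen-bond donor at this position, so that part of the change has no precedent here. On this basis compound 4 is expected to sit close to compound 3, with a step of about a 1.2-fold higher number from compound 3 to compound 4 (0.07 log units; within the scatter) in this assay, not beyond the scatter. The estimate for compound 4 is 120 nM, ranging from 50 nM to 300 nM.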

Compound 4, half-maximal inhibitory concentration: 23 nM
For compound 4 the middle estimate is 5.2-fold (0.72 log units) above the measured one; measured number outside the range, below it.
By their numbers in this assay, from the lowest: compound 4; then compounds 3, 1 and 2 (each within the scatter of the next).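

In this assay, this carbon proves sensitive to the group it carries: isopropylamino in place of piperidin-1-yl gives a step beyond the scatter (a 4.5-fold lower number from compound 3 to compound 4 (0.65 log units; beyond the scatter)), and the same holds for isopropylamino in place of dimethylamino (a 5.8-fold lower number from compound 1 to compound 4 (0.77 log units; beyond the scatter)). Variation among the earlier groups at this carbon had stayed within the scatter, so those compounds gave no sign of this range. Isopropylamino is also the only group here with a hydrogen-bond donor at this carbon, but this is an association across compound 1, compound 3 and compound 4, and nothing at hand accounts for the steps.

The change from piperidin-1-yl also swaps a ring for an open chain and adds a donor at once, so the two remain unseparated. Diisopropylamino, cyclohexylamino and ethylamino at this carbon would help to pull them apart.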